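The compounds below may be only part of what the source reports. "The series", "measured", "known", "first", "only" and "open" are said of these compounds alone.

Measured compounds in an assay on isolated protein for inhibition of inositol monophosphatase 1 (Bos taurus); on this read-out higher numbers stand for weaker inhibition and lower numbers for stronger inhibition:
compound 1 `O=C1CCCCC1CCCCO[C@@H]1C[C@H](O)C[C@@H](O)[C@H]1OS(=O)(=O)O` — 100000 nM
compound 2 `NS(=O)(=O)O[C@@H]1[C@H](O)C[C@@H](O)C[C@H]1OCCCCC1CCCCC1=O` — 200000 nM

Compound 2 gives the highest of the two numbers in this assay; its nearest neighbour is compound 1, with a 2.0-fold higher number from compound 1 to compound 2 (0.30 log units; within the scatter). Compound 3 `CC(=O)NS(=O)(=O)O[C@@H]1[C@H](O)C[C@@H](O)C[C@H]1OCCCCC1CCCCC1=O` differs from compound 2 by acetyl in place of hydrogen on a sulfonamide nitrogen. Among the measured compounds shown here, the only measured step, a 2.0-fold higher number from compound 1 to compound 2 (0.30 log units; within the scatter), changes the group on the sulfonyl sulfur and stays within the scatter; no measured step touches an acyl group on that nitrogen. No step beyond the scatter is therefore expected in this assay. For compound 3 the estimate is 200000 nM, range 60000 nM to 700000 nM. That estimate corresponds to no change at the digits printed from compound 2 to compound 3 (within the scatter), which is expected to stay within the scatter.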

Compound 3, half-maximal inhibitory concentration: > 300000 nM
Compound 3 ended at the assay's limit (the forecaster's own chance of this, stated with the estimate: 35%); middle value at least 1.5-fold (0.17 log units) away from the limit.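

In this assay compound 3 gives > 300000 nM as a limit of the assay and not a number. Acetyl in place of hydrogen on the sulfonamide nitrogen gives an at least 1.5-fold higher number from compound 2 to compound 3 (0.17 log units; that floor lies within the scatter) and this floor alone does not separate the two groups. Acetamido in place of hydroxy on the sulfonyl sulfur gives an at least 3.0-fold higher number from compound 1 to compound 3 (0.47 log units; beyond the scatter) and this is the first step in the series beyond the scatter, in the direction of weaker inhibition.

From the compounds shown here alone, the true distance between compound 2 and compound 3 stays open while the value of compound 3 is a limit. Also open, going by these compounds, is whether a methyl or a benzoyl on that nitrogen would give a lower number in this assay than hydrogen does.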